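Swapping Chloro for Amino: Expecting Little Change in Inhibition

A few compounds are considered here, and "the series" means these few. Any claim that something is new, unique, unknown or untested is made for them only; others in the source may bear on it.

Of the compounds shown here, three sharing one core have so far been tested in a functional assay on the whole organism for inhibition, with Mus musculus as the target, with a stated time of 1 h, at a dose of 30 mg/kg by the intraperitoneal route; a lower number here means less inhibition, a higher number more inhibition at the dose given (going by the name of the read-out). Compound 1 `O=C(/C=C/C1=Cc2ccccc2OC1)c1cccc(Cl)c1` gives 51%, compound 2 `O=C(/C=C/C1=Cc2ccccc2OC1)c1ccc(Cl)cc1` gives 56.1%, and compound 3 `CN(C)c1ccc(C(=O)/C=C/C2=Cc3ccccc3OC2)cc1` gives 57.3%. On these numbers compound 2 stands between the other two, yet all three lie within the usual scatter of one another, so none can be called stronger or weaker. The two steps touching compound 2 were both small: a number 5.1 percentage points higher from compound 1 to compound 2 (within the scatter), and a number 1.2 percentage points higher from compound 2 to compound 3 (within the scatter). Each changed a group on the ring attached to the carbonyl without moving the read-out beyond noise.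

Compound 4 `Nc1ccc(C(=O)/C=C/C2=Cc3ccccc3OC2)cc1` has not yet been measured. It differs from compound 2 in one place: amino in place of chloro on an aromatic carbon. The most relevant comparison is a number 1.2 percentage points higher from compound 2 to compound 3 (within the scatter), which likewise replaced the chloro with a nitrogen-bearing group and left the number essentially unchanged. The expected step of a number 1.1 percentage points lower from compound 2 to compound 4 (within the scatter) should therefore stay within the scatter, in no clear direction. Compound 4 is thus estimated to give about 55% in this assay, with a likely range from 40% to 70%.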

Compound 4, a percentage reported as inhibition, in the whole organism at one dose (the size of the read-out at that dose, not a potency): 52.6%
For compound 4 the middle estimate is 2.4 percentage points above the measured one; the measured number falls inside the stated range.
By their numbers in this assay, from the lowest: compounds 1, 4, 2 and 3 (each within the scatter of the next).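

In this assay, compound 4 cannot be told apart from its nearest relatives: a number 3.5 percentage points lower from compound 2 to compound 4 (within the scatter), and a number 4.7 percentage points lower from compound 3 to compound 4 (within the scatter). At this place, para to a large group, chloro, amino and dimethylamino therefore give readings that cannot be separated at this single dose, even though amino adds a hydrogen-bond donor that chloro lacks. The change from 3-chlorophenyl to 4-aminophenyl also leaves the reading within the scatter, with a number 1.6 percentage points higher from compound 1 to compound 4 (within the scatter), and no supporting measurement bears on these results.

On these data alone, it remains open whether a carboxylic acid, a nitrile or a longer chain such as butoxy at this place would shift the reading beyond the scatter. Because each reading comes from one dose, the compounds shown also leave open whether their potencies differ.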